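This account rests on a few compounds, and the source may have more. Where it says the series, first, only, none or still open, it means among the compounds named here.

In a toxicity assay on Vero cells (Chlorocebus sabaeus) (a higher number here means a weaker inhibitor, a lower number a stronger inhibitor), compound 1 `CCCCCCC(=O)c1cc(O)c(O)c(O)c1` stands at > 299000 nM as a limit, not a number. Compound 2 `CCCCCCCC(=O)c1cc(O)c(O)c(O)c1` stands at > 299000 nM as a limit too. Compound 3 `CCCCCCCCCCC(=O)c1cc(O)c(O)c(O)c1` is reached from compound 1 through butyl in place of hydrogen on a saturated chain carbon, six bonds along the chain from a carbonyl carbon and so carries butyl in place of hydrogen on a saturated chain carbon, six bonds along the chain from a carbonyl carbon. Among the measured compounds shown here, the one measured step bearing on this is a step that the two limits leave unreadable from compound 1 to compound 2 and the only evidence is the limit of > 299000 nM in this assay, at which 2 of the 2 values shown sit, so no size carries over. A modest shift towards stronger inhibition in this assay is tentatively expected, and another limit remains possible. The expected move is an at least 1.9-fold lower number from compound 1 to compound 3 (0.29 log units; that floor lies within the scatter) and nothing firmer. Compound 3 is estimated at 150000 nM within 40000 nM to 299000 nM as the expected range.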

Compound 3, half-maximal inhibitory concentration: > 299000 nM
Compound 3 was reported as a limit; the forecaster's own chance of this, stated with the estimate: 45%; at least 1.9-fold (0.29 log units) between middle value and limit.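

Among the compounds shown here, no step among compound 1, compound 2 and compound 3 can be read, as each is reported only as a limit: the limit of > 299000 nM in this assay, at which 3 of the 3 values shown sit. Going by these compounds, whether any chain length gives a readable number in this assay stays open.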